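The source may report more compounds than this note shows. Statements on the series, on what has been measured and on what is new or still open speak of the compounds shown alone.

Notes on the series built on the core of compound 1 `CC[C@@H](Nc1c(C#N)c(-c2ccc(-c3ccccc3F)cc2)nc2cnccc12)C(N)=O`. In a physicochemical assay for lipophilicity, read by HPLC, at pH 7.5 (a lower number here means a more polar compound, a higher number a more lipophilic compound), compound 1 gives 2.7, compound 2 `CC[C@@H](Nc1c(C#N)c(-c2ccc(-c3ccccc3COC)cc2)nc2cnccc12)C(N)=O` gives 2.6 and compound 3 `CC[C@@H](Nc1c(C#N)c(-c2ccc(-c3cccc(Cl)c3)cc2)nc2cnccc12)C(N)=O` gives 3.1. Compound 3 holds the highest of the three numbers, with steps of a number 0.40 log units higher from compound 1 to compound 3 (beyond the scatter) and a number 0.50 log units higher from compound 2 to compound 3 (beyond the scatter). The remaining step is a number 0.10 log units lower from compound 1 to compound 2 (within the scatter).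

Next in line is compound 4 `CC[C@@H](Nc1c(C#N)c(-c2ccc(-c3ccc(Cl)cc3)cc2)nc2cnccc12)C(N)=O`, which has the same atoms as compound 3, joined differently: 4-chlorophenyl in place of 3-chlorophenyl on an aromatic carbon. The chlorine changes position and nothing else does. Among the measured compounds shown here, no measured step isolates a change of that kind. For the measured compounds named here, the steps that bear on it most closely are the two into compound 3, and each of those replaces a whole substituted phenyl group, so neither sets a size for a shift of the chlorine alone. The change in this assay is therefore expected to stay within the scatter, with an expected step of no change at the digits printed from compound 3 to compound 4 (within the scatter). The estimate for compound 4 is 3.1, with an expected range of 2.8 to 3.4.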

Compound 4, distribution coefficient: 3.1
For compound 4 middle estimate and measured number coincide at the digits printed, within the range that was stated.
By their numbers in this assay, from the lowest: compounds 2 and 1 (each within the scatter of the next); then compounds 3 and 4 (each within the scatter of the next).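

In this assay, among the compounds shown here, moving the chlorine gives no change at the digits printed from compound 3 to compound 4 (within the scatter), the first measured step that changes only the position of that atom, and at this place 3-chlorophenyl and 4-chlorophenyl cannot be told apart. Compound 4 also repeats the gaps seen for compound 3, with a number 0.50 log units higher from compound 2 to compound 4 (beyond the scatter) and a number 0.40 log units higher from compound 1 to compound 4 (beyond the scatter), so among the compounds shown both chlorophenyl groups stand beyond the scatter of 2-fluorophenyl and 2-(methoxymethyl)phenyl. No evidence is at hand to account for either the unchanged number or these gaps.

Still open, on these data alone, is whether 2-chlorophenyl would read with the other two chlorophenyl groups, which would separate the effect of the chlorine from that of its position. Also open, as far as these compounds go, is how an amine or a carboxylic acid on this same ring would read in this assay.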